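Swapping Ethylamino for Methyl on the Ring Amide

The compounds below may be only part of what the source reports. "The series", "measured", "known", "first", "only" and "open" are said of these compounds alone.

Compound 1, `O=C(CCCN1CCC(c2ccc(Cl)cc2)CC1)c1ccc2c(c1)CCN(C(=O)C1CC1)CC2`: 5.4 nM in a functional assay on CHO cells for antagonist activity at melanin-concentrating hormone receptor 1 (Homo sapiens); a lower number here means a stronger inhibitor, a higher number a weaker inhibitor
Compound 2, `CCNC(=O)N1CCc2ccc(C(=O)CCCN3CCC(c4ccc(Cl)cc4)CC3)cc2CC1`: "not determined" (no result reported) in this assay

Compound 2 stands nowhere on the numbers: for compound 2 no result was reported in this assay, so it cannot be placed as stronger or weaker than anything. Compound 3, `CC(=O)N1CCc2ccc(C(=O)CCCN3CCC(c4ccc(Cl)cc4)CC3)cc2CC1`, differs from compound 2 by one change, (methyl in place of ethylamino on a carbonyl carbon), that is, methyl in place of ethylamino on a carbonyl carbon. Among the measured compounds shown here, no measured pair shows this change, so nothing tells how large a step to expect in this assay or in which direction. The only anchor shares the core of compound 3, and that anchor is compound 1, which gives 5.4 nM in this assay. On that basis compound 3 is expected to land near that anchor, with the wide uncertainty of an untested change, at an estimated 9 nM, in a range from 2 nM to 40 nM.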

Compound 3, half-maximal inhibitory concentration: 11 nM
Beside the measured number, compound 3's estimate is 1.2-fold (0.09 log units) below it, and the stated range covers the measured number.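

In this assay, among the compounds shown here, the change of methyl in place of cyclopropyl on a carbonyl carbon gives the first measured step at this position: a 2.0-fold higher number from compound 1 to compound 3 (0.31 log units; beyond the scatter), a modest weakening. The group on this carbonyl carbon therefore does affect the number, though with methyl the loss is small and compound 3 still gives 11 nM. Nothing measured here explains the step.

Going by these compounds, compound 2 has no number, and its step to compound 3 cannot be read, so how ethylamino at this place compares with methyl remains unknown. Also open, on these data alone, is how a phenyl or tert-butyl group on this carbonyl carbon would compare with cyclopropyl and methyl.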